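From dimethylamino to diethylamino on compound 2

A few compounds are considered here, and "the series" means these few. Any claim that something is new, unique, unknown or untested is made for them only; others in the source may bear on it.

In a functional assay on U-937 cells (Homo sapiens) for antiproliferative activity, read by CCK-8 assay, with a stated time of 24 h (on this read-out lower numbers stand for stronger inhibition and higher numbers for weaker inhibition), three related compounds have been measured so far. Compound 1 (`C/C(=N\NC(=O)Nc1nc2ccc(CN(C)C)cc2s1)c1ccccn1`) gives 20100 nM, compound 3 (`CCN(CC)Cc1ccc2nc(NC(=O)N/N=C/c3ccccn3)sc2c1`) gives 24800 nM, and compound 2 (`CN(C)Cc1ccc2nc(NC(=O)NN=C(c3ccccn3)c3ccccn3)sc2c1`) gives 7800 nM. Compound 2 thus has the lowest of the three numbers, and its gap to each of the others lies beyond the usual scatter.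

Compound 4 (`CCN(CC)Cc1ccc2nc(NC(=O)NN=C(c3ccccn3)c3ccccn3)sc2c1`) has not yet been measured. It keeps all of compound 2 except one group: diethylamino in place of dimethylamino on a saturated chain carbon bound to an aromatic carbon, with diethylamino in place of dimethylamino on a saturated chain carbon bound to an aromatic carbon. Within the data shown here, no measured pair differs by this change alone, so the data give no direct guide to its effect. Compound 3 also carries diethylamino, but it differs from compound 2 elsewhere as well, so it cannot isolate the change. With compound 2 at 7800 nM as the starting point, the estimated step of a 1.2-fold higher number from compound 2 to compound 4 (0.06 log units; within the scatter) is expected to stay within the scatter. For compound 4 the expected value is 9000 nM, with a range from 3500 nM to 20000 nM.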

Compound 4, half-maximal inhibitory concentration: 9100 nM
For compound 4 the middle estimate is 1.0-fold (0.00 log units) below the measured one; measured number inside the range.
By their numbers in this assay, from the lowest: compounds 2 and 4 (each within the scatter of the next); then compounds 1 and 3 (each within the scatter of the next).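

In this assay, among these compounds, the step of a 1.2-fold higher number from compound 2 to compound 4 (0.07 log units; within the scatter) lies within the scatter, and this is the first pair of compounds that differ only in this change. On this core, with the group on a saturated chain carbon bound to an aromatic carbon, diethylamino and dimethylamino cannot be told apart, even though diethylamino carries more heavy atoms. Nothing available explains why the two numbers agree.

Going by these compounds, whether this tolerance extends to ring amines such as morpholine or piperidine, or to a longer chain such as dipropylamino, stays open. Also open, on these data alone, is whether the same swap would give a similarly small step on the cores of compound 1 or compound 3, since each appears here with only one of the two amines.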